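Triazolothiadiazine series: cytotoxicity on HT-29 cells

The source may report more compounds than this note shows. Statements on the series, on what has been measured and on what is new or still open speak of the compounds shown alone.

Measured so far:
compound 1, `COc1ccc(/C=N/n2c(SCc3ccccc3Cl)nnc2-c2cc(OC)c(OC)c(OC)c2)c(OC)c1`: > 200000 nM
compound 2, `COc1cc(-c2nnc3n2NC(CC(=O)c2ccc(C)cc2)(c2ccccc2)S3)cc(OC)c1OC`: 151000 nM
compound 3, `CCOC(=O)CC1(c2ccccc2)Nn2c(nnc2-c2cc(OC)c(OC)c(OC)c2)S1`: > 200000 nM

Among the compounds with values here, in a functional assay on HT-29 cells (Homo sapiens) for cytotoxicity, read by MTT assay, with a stated time of 48 h (on this read-out lower numbers stand for stronger inhibition and higher numbers for weaker inhibition), compound 2 gives 151000 nM, the only value in the set that is a number. For compound 1 the result > 200000 nM is a limit of this assay, not a number. For compound 3 the result > 200000 nM is likewise a limit. Within the data shown here, the one step that can be put in numbers, an at least 1.3-fold higher number from compound 2 to compound 3 (0.12 log units; that floor lies within the scatter), has a floor that sits within the scatter; its size is open upward, as the limit of > 200000 nM in this assay, at which 2 of the 3 values shown sit, shows.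

Compound 4, `COc1ccc(C2(CC(=O)c3ccc(C)cc3)Nn3c(nnc3-c3cc(OC)c(OC)c(OC)c3)S2)c(OC)c1`, differs from compound 2 by 2,4-dimethoxyphenyl in place of phenyl on a saturated ring carbon. Among the measured compounds shown here, no measured step touches this part of the core; the only measured change, from compound 2 to compound 3, lies on the carbonyl carbon and therefore says nothing about the saturated ring carbon. With nothing to point either way, no step beyond the scatter is expected in this assay, so a 1.1-fold higher number from compound 2 to compound 4 (0.03 log units; within the scatter) is the expected outcome. Compound 4 is therefore estimated at 160000 nM, within 60000 nM to 400000 nM, with a real chance that this assay returns only a limit.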

Compound 4, half-maximal inhibitory concentration: 66800 nM
Compound 4: middle estimate off by 2.4-fold (0.38 log units), on the high side; the measured number falls inside the stated range.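

Within the data shown here, the saturated ring carbon responds to substitution in this assay: 2,4-dimethoxyphenyl in place of phenyl gives a 2.3-fold lower number from compound 2 to compound 4 (0.35 log units; beyond the scatter), the first modest step in the set that clearly lies beyond the scatter. The earlier compounds shown here showed a change only on the carbonyl carbon, where the measurable floor stayed within the scatter, so they gave no reading of this position. Nothing in the data at hand gives a reason for this step.

Open, on these data alone, is whether one methoxy group alone, at either place on the phenyl ring, would carry the same step, or whether an amine or a carboxylic acid on that ring would move the number further. Also open, as far as these compounds go, is whether the 2,4-dimethoxyphenyl change would have the same effect with ethoxy on the carbonyl carbon, as in compound 3.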